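Anilino series: removing the ortho fluorine from compound 3

The source may report more compounds than this note shows. Statements on the series, on what has been measured and on what is new or still open speak of the compounds shown alone.

Working notes. Three analogues of one shared core have been run in a functional assay on MCF7 cells (Homo sapiens) for inhibition, read by MTT assay, with a stated time of 72 h; a higher number here means a weaker inhibitor, a lower number a stronger inhibitor. Compound 1 `COc1ccc(Nc2nc(SCc3cn(Cc4ccccc4Cl)nn3)nc(-c3ccccc3)c2C#N)cc1` gives 8050 nM. Compound 2 `COc1ccccc1Nc1nc(SCc2cn(Cc3ccccc3Cl)nn2)nc(-c2ccccc2)c1C#N` gives 6170 nM. Compound 3 `N#Cc1c(Nc2ccccc2F)nc(SCc2cn(Cc3ccccc3Cl)nn2)nc1-c1ccccc1` gives 8060 nM. Compound 3 carries the largest of the three numbers, but a 1.0-fold higher number from compound 1 to compound 3 (0.00 log units; within the scatter) and a 1.3-fold higher number from compound 2 to compound 3 (0.12 log units; within the scatter) both sit within the scatter, so the three compounds stand level on what is shown; a 1.3-fold lower number from compound 1 to compound 2 (0.12 log units; within the scatter) likewise stays within the scatter.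

Compound 4 `N#Cc1c(Nc2ccccc2)nc(SCc2cn(Cc3ccccc3Cl)nn2)nc1-c1ccccc1` is not yet measured. It differs from compound 3 by hydrogen in place of fluoro on an aromatic carbon, the position being on an aromatic carbon of a six-membered aromatic ring of carbon only, ortho to a large group. The changes on the same ring seen so far, a 1.3-fold higher number from compound 2 to compound 3 (0.12 log units; within the scatter) and a 1.0-fold higher number from compound 1 to compound 3 (0.00 log units; within the scatter), swapped one small group for another there and moved nothing beyond the scatter. Taking fluoro away altogether is a change of similar scale, so the expected step of a 1.0-fold lower number from compound 3 to compound 4 (0.00 log units; within the scatter) is none beyond the scatter. Compound 4 is therefore estimated at 8000 nM, with a range from 4000 nM to 16000 nM in this assay.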

Compound 4, half-maximal inhibitory concentration: > 64000 nM
Compound 4: a limit, no number; the forecaster's own chance of this, stated with the estimate: 5%; at least 8.0-fold (0.90 log units) between middle value and limit.
By their numbers in this assay, from the lowest: compounds 2, 1 and 3 (each within the scatter of the next). At a limit, above all of these: compound 4.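

In this assay compound 4 gives a limit, not a number: the limit of > 64000 nM in this assay, at which 1 of the 4 values shown sits. With hydrogen in place of fluoro the series shows an at least 7.9-fold higher number from compound 3 to compound 4 (0.89 log units; beyond the scatter), and with hydrogen in place of methoxy it shows an at least 10-fold higher number from compound 2 to compound 4 (1.01 log units; beyond the scatter) and an at least 7.9-fold higher number from compound 1 to compound 4 (0.90 log units; beyond the scatter). Swaps among 2-fluorophenyl, 2-methoxyphenyl and 4-methoxyphenyl moved nothing beyond the scatter, so among these four compounds the divide lies between a substituted ring and plain anilino, not between one substituent and another.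

As far as these compounds go, whether a chloro, a methyl or an amine on this ring would stand level with compounds 1, 2 and 3 or go the way of compound 4 remains open. Also open, from the compounds shown here alone, is whether a substituent at any place on the ring serves equally, since fluoro appears at only one place.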